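This account rests on a few compounds, and the source may have more. Where it says the series, first, only, none or still open, it means among the compounds named here.

Measured compounds:
compound 1 `Cn1ncnc1-c1cc(Oc2ccc(NC(=O)Nc3cccc(C(F)(F)F)c3)cc2F)ccn1`, 9680 nM;
compound 2 `Cn1cnnc1-c1cc(Oc2ccc(NC(=O)Nc3cccc(C(F)(F)F)c3)cc2F)ccn1`, 6470 nM;
compound 3 `CN(C)CCn1cnnc1-c1cc(Oc2ccc(NC(=O)Nc3ccccc3C(F)(F)F)cc2F)ccn1`, > 50000 nM.

These three compounds were tested in a functional assay on MDA-MB-231 cells (Homo sapiens) for antiproliferative activity, read by MTT assay, with a stated time of 72 h; on this read-out higher numbers stand for weaker inhibition and lower numbers for stronger inhibition. Compound 1 and compound 2 share the diaryl urea with the trifluoromethyl group on one outer ring and differ only in the triazole, and the step of a 1.5-fold lower number from compound 1 to compound 2 (0.17 log units; within the scatter) lies within the scatter. Compound 3 carries the trifluoromethyl group at a different place on that outer ring and a dimethylaminoethyl chain on its triazole; for compound 3 this assay gives only a limit, > 50000 nM, so the value is not a number and sits at the limit of > 50000 nM in this assay, at which 1 of the 3 values shown sits.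

Compound 4 `CN(C)CCn1cnnc1-c1cc(Oc2ccc(NC(=O)Nc3ccc(Cl)cc3Cl)cc2F)ccn1` is the unmeasured partner of compound 3. The change is 2,4-dichlorophenyl in place of 2-(trifluoromethyl)phenyl on an amide-type nitrogen. Going by the values given here, none of the measured steps bears on this change: the only measured step concerns the triazole, not the outer aryl ring. Where compound 4 will stand is therefore open, and the expectation rests on compound 3 alone. The estimated step is an at least 2.0-fold lower number from compound 3 to compound 4 (0.30 log units; that floor lies within the scatter), and compound 4 is expected to give about 25000 nM, within 3000 nM to 50000 nM, with a real chance that only a limit is reported again.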

Compound 4, half-maximal inhibitory concentration: 7960 nM
The estimate for compound 4 lay 3.1-fold (0.50 log units) above the measured number; measured number inside the range.
By their numbers in this assay, from the lowest: compounds 2, 4 and 1 (each within the scatter of the next). At a limit, above all of these: compound 3.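

In this assay, the outer aryl ring on the amide-type nitrogen proves to matter: with the dimethylaminoethyl chain held on the triazole, 2,4-dichlorophenyl in place of 2-(trifluoromethyl)phenyl gives an at least 6.2-fold lower number from compound 3 to compound 4 (0.79 log units; beyond the scatter). The earlier measured step touched only the triazole and stayed within the scatter, so this is the first change shown to move the number beyond it, and compound 4 shows that the dimethylaminoethyl chain does not by itself rule out a measurable number. The size of the step has only a floor, since compound 3 stands at a limit and not at a number: the limit of > 50000 nM in this assay, at which 1 of the 4 values shown sits.

The compounds shown do not tell whether a single chlorine would do the same, or whether the step would hold with a methyl on the triazole instead of the chain. Nor do they show how a nitrile on that outer ring, or a morpholine in place of the dimethylamino end of the chain, would read.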